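Diyne chain shortening in the HL-60 series

The source may report more compounds than this note shows. Statements on the series, on what has been measured and on what is new or still open speak of the compounds shown alone.

Measured compounds:
compound 1 `CC(=O)OC/C=C/C=C/C#CC/C=C\CCCCCCCCOC(C)=O`, > 10000 nM
compound 2 `OC/C=C/C=C/C#CC/C=C\CCCCCCCCO`, > 10000 nM
compound 3 `OC/C=C\C#CC#CC/C=C\CCCCCCCCO`, > 10000 nM

In a functional assay on HL-60 cells (Homo sapiens) for inhibition, read by MTT assay, with a stated time of 3 days (on this read-out lower numbers stand for stronger inhibition and higher numbers for weaker inhibition), compound 1 gives > 10000 nM, which is a limit of the assay. Compound 2 likewise gives > 10000 nM, a limit. Compound 3 stands at > 10000 nM, again a limit, so its position is not a number but a bound; this is the limit of > 10000 nM in this assay, at which 3 of the 3 values shown sit. Going by the values given here, the one step among measured compounds, a step that the two limits leave unreadable from compound 2 to compound 3, is therefore unreadable in size. Compound 4 `CCCCC/C=C\CC#CC#C/C=C\CO` differs from compound 3 by hydrogen in place of 3-hydroxypropyl on a saturated chain carbon, five bonds along the chain from a double-bonded chain carbon. Among the compounds with values here, no measured step bears on this change. No direction beyond the scatter is expected for an at least 1.2-fold lower number from compound 3 to compound 4 (0.09 log units; that floor lies within the scatter) in this assay. Compound 4 is estimated at 8000 nM, within 1500 nM to 30000 nM.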

Compound 4, half-maximal inhibitory concentration: 11000 nM
Compound 4: the middle estimate sits 1.4-fold (0.14 log units) below what was measured; low and high end bracket the measured number.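

The step from compound 3 to compound 4 cannot be read in size, and compound 3 remains only a limit: the limit of > 10000 nM in this assay, at which 3 of the 4 values shown sit.

As far as these compounds go, whether hydrogen in place of 3-hydroxypropyl changes the inhibition at all stays open.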